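Hydroxy in place of diethylamino on a saturated chain

A few compounds are considered here, and "the series" means these few. Any claim that something is new, unique, unknown or untested is made for them only; others in the source may bear on it.

Three amides sharing one core have been tested in a functional assay on PC-3 cells (Homo sapiens) for antiproliferative activity, read by MTT assay, with a stated time of 24 h (a higher number here means a weaker inhibitor, a lower number a stronger inhibitor), so far. Compound 1 (`CCn1c(C(=O)N[C@@H](C)C(=O)OC)ccc1C(CC)(CC)c1ccc(OCS(=O)(=O)c2ccccc2)c(C)c1`) gives > 50000 nM and this is a limit of the assay, not a number. Compound 2 (`CCn1c(C(=O)NCCC(=O)OC)ccc1C(CC)(CC)c1ccc(OCS(=O)(=O)c2ccccc2)c(C)c1`) gives 40400 nM while compound 3 (`CCN(CC)CCNC(=O)c1ccc(C(CC)(CC)c2ccc(OCS(=O)(=O)c3ccccc3)c(C)c2)n1CC`) gives 7130 nM which is the lowest number of the set. Compound 4 (`CCn1c(C(=O)NCCO)ccc1C(CC)(CC)c1ccc(OCS(=O)(=O)c2ccccc2)c(C)c1`) has not yet been measured. It departs from compound 3 as follows: hydroxy in place of diethylamino on a saturated chain carbon, two bonds along the chain from an amide-type nitrogen in words, hydroxy in place of diethylamino on a saturated chain carbon, two bonds along the chain from an amide-type nitrogen.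

The nearest evidence is a 5.7-fold lower number from compound 2 to compound 3 (0.75 log units; beyond the scatter) where diethylamino replaced methoxycarbonyl at this same place. The comparison an at least 7.0-fold lower number from compound 1 to compound 3 (0.84 log units; beyond the scatter) points the same way, whereas an at least 1.2-fold lower number from compound 1 to compound 2 (0.09 log units; that floor lies within the scatter) adds little. For the measured compounds named here, no tested compound carries hydroxy here, so the size of the change remains uncertain. Removing diethylamino is expected to undo much of the step to compound 3, with a higher number and not a lower one. The estimated change is a 3.9-fold higher number from compound 3 to compound 4 (0.59 log units; beyond the scatter) in this assay as a result. Compound 4 is expected at 28000 nM with an estimated range from 12000 nM to 55000 nM in this assay when it is measured.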

Compound 4, half-maximal inhibitory concentration: 17700 nM
Compound 4: the middle estimate sits 1.6-fold (0.20 log units) above what was measured; measured number inside the range.
By their numbers in this assay, from the lowest: compound 3; then compound 4; then compound 2. At a limit, above all of these: compound 1.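

In this assay, hydroxy at this place lies on neither extreme of the groups seen so far: a 2.5-fold higher number from compound 3 to compound 4 (0.39 log units; beyond the scatter), yet a 2.3-fold lower number from compound 2 to compound 4 (0.36 log units; beyond the scatter). The earlier compounds shown here showed only that diethylamino gave a lower number than methoxycarbonyl, and this result shows that a much smaller group, with 1 heavy atom in place of 5, also gives a lower number than methoxycarbonyl, though it does not reach the number of compound 3. Compound 1 stands at a limit of the assay and not at a number, so an at least 2.8-fold lower number from compound 1 to compound 4 (0.45 log units; beyond the scatter) is only a floor: the limit of > 50000 nM in this assay, at which 1 of the 4 values shown sits.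

The compounds shown leave open whether another amine at this place, such as dimethylamino or a primary amine, or a carboxylic acid in place of the methyl ester, would fall nearer compound 3 or nearer compound 4. They also leave open how a longer chain carrying the hydroxy or the diethylamino would alter the number in this assay.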